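Aryl Group Exchange on Compound 3

The source may hold more compounds than are shown below. What is called first, only, known or untested is meant among the compounds shown, and "the series" means these compounds.

Measured compounds:
compound 1, `Cc1cc(NC(=S)Cn2nnc(-c3ccccc3)n2)n(C2CCCCC2)n1`, 80%
compound 2, `Cc1cc(NC(=O)Cn2nnc(-c3ccccc3)n2)n(C2CCS(=O)(=O)CC2)n1`, > 25%
compound 3, `Cc1cc(NC(=O)Cn2nnc(-c3ccccc3F)n2)n(C2CCCCC2)n1`, 88%

Of the compounds shown here, three have been tested in an assay on HEK293 cells for activation of Kir3.1/Kir3.2 (Homo sapiens), read by thallium flux; a higher number here means a larger maximal response, a lower number a smaller maximal response. Compound 3 gives 88%, and compound 1 gives 80%; the gap between compound 3 and compound 1 lies within the usual scatter, so the two cannot be told apart. The value of compound 2, > 25%, is a limit of the assay and not a number, which is the case for one of the three values shown (the limit of > 25% in this assay, at which 1 of the 3 values shown sits). Among the two actual numbers, compound 3 has the higher one.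

Going by the values given here, the unmeasured compound 4, `Cc1cc(NC(=O)Cn2nnc(-c3cccc(C(F)(F)F)c3)n2)n(C2CCCCC2)n1`, is compound 3 with a different aryl group. 3-(trifluoromethyl)phenyl in place of 2-fluorophenyl on an aromatic carbon No measured pair in this set differs by a comparable change, so there is no measured step to lean on. Since compound 1 and compound 3, with different amide-side and aryl variations, sit within the scatter of each other, the maximal response of compound 4 is expected to stay in the same range, with the step of a number 4 percentage points lower from compound 3 to compound 4 (within the scatter) expected to be no more than the scatter. Compound 4 is therefore estimated at 84%, between 62% and 100%.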

Compound 4, largest response reached (Emax), in percent of the reference or control that the assay uses: 86%
Compound 4: middle estimate off by 2 percentage points, on the low side; the range from low to high includes it.
By their numbers in this assay, from the lowest: compounds 1, 4 and 3 (each within the scatter of the next).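

In this assay, going by these compounds alone, the exchange of 2-fluorophenyl for 3-(trifluoromethyl)phenyl provides the only measured step at this position, an aromatic carbon of the five-membered aromatic ring with 4 nitrogen, and that step is a number 2 percentage points lower from compound 3 to compound 4 (within the scatter). Within the data shown here, the earlier compounds held no pair that differed in one place, so this is the first direct reading of a change here: an aryl group of 10 heavy atoms, 3 of them fluorine, stands in place of one of 7 heavy atoms, a single fluorine among them, with no difference that can be told from the scatter. That reading holds for this one pair only, and nothing in the data shown offers a reason for it.

The compounds shown leave open whether the largest response persists when the phenyl ring at this position carries an amine or a carboxylic acid, or when a pyridine ring or a longer chain takes its place. As far as these compounds go, it also remains open whether 3-(trifluoromethyl)phenyl would behave the same way on the core of compound 2.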